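Swapping the aryl group on a chalcone-like scaffold

The source may hold more compounds than are shown below. What is called first, only, known or untested is meant among the compounds shown, and "the series" means these compounds.

Within the data shown here, compound 1 `COc1ccc(/C=C/C(=O)c2ccc(OC)c3c2OC(C)(C)C=C3)c(F)c1` is one of two compounds measured in a functional assay on SK-OV-3 cells (Homo sapiens) for antiproliferative activity, read by MTT assay, with a stated time of 24 h (on this read-out higher numbers stand for weaker inhibition and lower numbers for stronger inhibition), in which compound 1 gives 4880 nM. This is the highest of the two numbers; the other belongs to compound 2 `COc1ccc(C(=O)/C=C/c2ccc3ccccc3n2)c2c1C=CC(C)(C)O2`, which in this assay gives 2350 nM, a difference that lies beyond the usual scatter. The new compound 3 `COc1ccc(C(=O)/C=C/c2cccc([N+](=O)[O-])c2)c2c1C=CC(C)(C)O2` keeps the shared core of compound 1 and changes only the aryl group attached to the chain: 3-nitrophenyl in place of 2-fluoro-4-methoxyphenyl on a double-bonded chain carbon bound to a double-bonded chain carbon. Among the measured compounds shown here, no measured pair shows exactly this exchange, so there is no directly comparable step to lean on. The expectation for the step from compound 1 to compound 3 in this assay is a modest move toward a lower number, a 1.6-fold lower number from compound 1 to compound 3 (0.21 log units; within the scatter), though a result within the scatter would not be surprising. Compound 3 is therefore estimated at 3000 nM, with a plausible range from 800 nM to 12000 nM.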

Compound 3, half-maximal inhibitory concentration: 9720 nM
Estimate against measurement, compound 3: 3.2-fold (0.51 log units) below; measured number inside the range.
By their numbers in this assay, from the lowest: compound 2; then compounds 1 and 3 (each within the scatter of the next).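

In this assay, placing 3-nitrophenyl in place of 2-fluoro-4-methoxyphenyl on a double-bonded chain carbon bound to a double-bonded chain carbon gives a 2.0-fold higher number from compound 1 to compound 3 (0.30 log units; within the scatter) for this exchange. Among these compounds, this is the first step at this position that can be read directly, and it shows that these two differently substituted aryl groups cannot be told apart in this measurement, so neither compound can be ranked over the other. No measurement shown here bears on the cause of this result.

Going by these compounds, it remains open whether any other group at this position would give a step beyond the scatter. A phenyl ring carrying an amine or a carboxylic acid would test this, and it could also show how much the ring's substituents matter here.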